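Amino for Bromo: an Expected Step in Potency

A few compounds are considered here, and "the series" means these few. Any claim that something is new, unique, unknown or untested is made for them only; others in the source may bear on it.

Compound 3 `O=C(CCCCCc1ccc(Br)cc1)N1CCOC1=O` sits second highest of the three numbers in an assay on HEK293 cells for inhibition of N-acylethanolamine-hydrolyzing acid amidase (Rattus norvegicus), read by LC-MS, with a stated time of 30 min (on this read-out higher numbers stand for weaker inhibition and lower numbers for stronger inhibition), where compound 3 gives 8510 nM. Compound 2 `O=C(CCCCCc1cccc(O)c1)N1CCOC1=O` gives 8640 nM, a value within the scatter of compound 3, so the two cannot be ordered. Compound 1 `O=C(CCCCCc1cccc(I)c1)N1CCOC1=O` gives 3120 nM, the lowest of the three. Compound 4 `Nc1ccc(CCCCCC(=O)N2CCOC2=O)cc1` is not yet measured; it differs from compound 3 by amino in place of bromo on an aromatic carbon. Among the compounds with values here, only one measured step bears on a group carrying a hydrogen-bond donor taking the place of a halogen: a 2.8-fold higher number from compound 1 to compound 2 (0.44 log units; beyond the scatter), a modest weakening. That step concerns hydroxy for iodo rather than amino for bromo, so it guides only loosely. The account therefore expects a step of similar size in the same direction for compound 4, namely a 1.8-fold higher number from compound 3 to compound 4 (0.25 log units; within the scatter) in this assay. Compound 4 is accordingly estimated at 15000 nM, with a range from 5000 nM to 45000 nM.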

Compound 4, half-maximal inhibitory concentration: 15700 nM
Estimate against measurement, compound 4: 1.0-fold (0.02 log units) below; the measured number falls inside the stated range.
By their numbers in this assay, from the lowest: compound 1; then compounds 3, 2 and 4 (each within the scatter of the next).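

In this assay, the change at this position gives a 1.8-fold higher number from compound 3 to compound 4 (0.27 log units; within the scatter), so amino and bromo cannot be told apart here. Within the data shown here, the earlier step, with hydroxy in place of iodo, lay beyond the scatter; this is the first reading for a group with a hydrogen-bond donor in place of a halogen on an aromatic carbon para to a large group, and it shows no change that can be separated from the scatter. Nothing measured here gives a reason for this result.

On these data alone, whether hydroxy, methoxy or a carboxylic acid at this place would also stay within the scatter of bromo remains open. As far as these compounds go, it is also open whether amino at the place that carries iodo in compound 1 would give a step beyond the scatter.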